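The compounds below may be only part of what the source reports. "The series", "measured", "known", "first", "only" and "open" are said of these compounds alone.

Of the compounds shown here, three built on one shared core have been measured so far. Compound 1 `Nc1nc(-c2ccc(Cl)cc2)c(CC(=O)O)s1` is the smallest of them. In an in vitro functional assay on HEK285-7 cells for antagonist activity at prostaglandin D2 receptor 2 (Homo sapiens), read by BRET and beta-arrestin recruitment (on this read-out lower numbers stand for stronger inhibition and higher numbers for weaker inhibition), compound 1 gives > 100000 nM, which is a limit of the assay and not a number. Compound 2 `O=C(O)Cc1sc(C(c2ccc(F)cc2)c2ccc(F)cc2)nc1-c1ccnc(N2CCC2)c1` is far larger. In this assay compound 2 gives > 100000 nM, again a limit rather than a measured number. Compound 3 `O=C(O)Cc1sc(C(c2ccccc2)c2ccccc2)nc1-c1ccc(C(F)(F)F)cc1` gives > 100000 nM in this assay, also a limit. Among the compounds with values here, compound 2 therefore stands exactly where every value so far sits, at the limit of > 100000 nM in this assay, at which 3 of the 3 values shown sit; nothing separates it from the others.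

The unmeasured compound 4 `N#Cc1ccc(-c2nc(C(c3ccc(F)cc3)c3ccc(F)cc3)sc2CC(=O)O)cc1` differs from compound 2 in one place: 4-cyanophenyl in place of 2-(azetidin-1-yl)pyridin-4-yl on an aromatic carbon. Within the data shown here, no step between two measured numbers exists in these data, so the change has no precedent to lean on. Since compound 3, which shares the core and also ends at > 100000 nM, shows no activity either, the step is expected to be a number no higher from compound 2 to compound 4 (the limit leaves the size open), nothing beyond the usual scatter. Compound 4 is thus expected to give 100000 nM in this assay, within a range from 20000 nM to 300000 nM, most likely reported again only as a limit.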

Compound 4, half-maximal inhibitory concentration: 1500 nM
Estimate against measurement, compound 4: 67-fold (1.82 log units) above, outside the stated range (below it).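

In this assay, the group on the aromatic carbon next to the ring nitrogen proves able to move the read-out: 4-cyanophenyl in place of 2-(azetidin-1-yl)pyridin-4-yl gives an at least 66-fold lower number from compound 2 to compound 4 (1.82 log units; beyond the scatter). Compound 2 gives > 100000 nM, which is a limit of the assay, so the true size of this step remains undetermined. Compound 4 is the one compound shown that comes off this limit, something the earlier compounds could not show: the limit of > 100000 nM in this assay, at which 3 of the 4 values shown sit.

The compounds shown do not separate the part played by the nitrile from that of the carbon-only aromatic ring, as the two enter together. On these data alone, it also remains open whether an amine or a methoxy group in place of the nitrile would keep the number this low.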